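One More Carbon on a Growing Chain

The source may hold more compounds than are shown below. What is called first, only, known or untested is meant among the compounds shown, and "the series" means these compounds.

Of the compounds shown here, three sharing one core have been measured in a functional assay on MGC-803 cells (Homo sapiens) for inhibition, read by MTT assay, with a stated time of 72 h (a lower number here means a stronger inhibitor, a higher number a weaker inhibitor), so far. Compound 1 (`Cc1ccc(NC(=O)C2CCN(C/C=C/c3ccccc3)CC2)cc1`) gives 24100 nM, compound 2 (`CC(C)c1ccc(NC(=O)C2CCN(C/C=C/c3ccccc3)CC2)cc1`) gives 5200 nM and compound 3 (`CCCCc1ccc(NC(=O)C2CCN(C/C=C/c3ccccc3)CC2)cc1`) gives 2570 nM, the lowest number of the three and so the strongest inhibitor among them.

The next compound, compound 4 (`CCCCCc1ccc(NC(=O)C2CCN(C/C=C/c3ccccc3)CC2)cc1`), changes only the end of the butyl chain of compound 3: methyl in place of hydrogen on a saturated chain carbon, four bonds along the chain from an aromatic carbon. Put simply, it has a methyl in place of hydrogen on a saturated chain carbon, four bonds along the chain from an aromatic carbon.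

Going by the values given here, two measured steps bear on this change. Isopropyl in place of methyl on an aromatic carbon gave a 4.6-fold lower number from compound 1 to compound 2 (0.67 log units; beyond the scatter), and butyl in place of isopropyl gave a 2.0-fold lower number from compound 2 to compound 3 (0.31 log units; beyond the scatter). Taken together, the change across this series is a 9.4-fold lower number from compound 1 to compound 3 (0.97 log units; beyond the scatter). Among these three compounds, bigger groups go with lower numbers, but the second step is the smaller one, and no measurement yet shows where the run ends.

A small further fall is therefore the best guess, and the expected step is a 1.4-fold lower number from compound 3 to compound 4 (0.13 log units; within the scatter). In this assay the estimate for compound 4 is 1900 nM, with an expected range from 850 nM to 4200 nM.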

Compound 4, half-maximal inhibitory concentration: 2550 nM
Compound 4: the middle estimate sits 1.3-fold (0.13 log units) below what was measured; low and high end bracket the measured number.
By their numbers in this assay, from the lowest: compounds 4 and 3 (each within the scatter of the next); then compound 2; then compound 1.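

In this assay, going by these compounds alone, methyl in place of hydrogen, four bonds along the chain from an aromatic carbon, gives a 1.0-fold lower number from compound 3 to compound 4 (0.00 log units; within the scatter) and so, unlike the earlier steps, leaves the number within the scatter. Pentyl in place of isopropyl gives a 2.0-fold lower number from compound 2 to compound 4 (0.31 log units; beyond the scatter) and the whole lengthening of the chain gives a 9.5-fold lower number from compound 1 to compound 4 (0.98 log units; beyond the scatter) and these two steps show that the pentyl chain of compound 4 keeps the gain reached with the butyl chain of compound 3 but adds nothing that can be told apart from the scatter. Nothing measured here explains why the chain stops paying off at this length.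

With a longer chain such as hexyl or octyl the number could stay level, rise or fall again, so one flat step does not yet mark the end of the run. On these data alone, how a hydroxyl group or an amine in place of this methyl would compare also remains open.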